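Swapping Methoxy for Dimethylamino on Compound 2

This account rests on a few compounds, and the source may have more. Where it says the series, first, only, none or still open, it means among the compounds named here.

Among the compounds with values here, compound 2 `COc1ccc(Cl)cc1Nc1nc2c(s1)CCCCc1nc(NC(=O)C(C)(C)C)sc1-2` gives the lowest of the two numbers measured so far in an assay on cells (Epithelial cell) with Cystic fibrosis transmembrane conductance regulator variant F508del (Homo sapiens) as the target, read by fluorescence, with a stated time of 20 h (on this read-out higher numbers stand for weaker inhibition and lower numbers for stronger inhibition), at 4100 nM. Compound 1 `COc1ccc(Cl)cc1Nc1nc2c(s1)CCCCc1nc(N)sc1-2` gives 9200 nM in this assay, and the step of a 2.2-fold lower number from compound 1 to compound 2 (0.35 log units; beyond the scatter) came from placing a tert-butylcarbonyl group on a ring nitrogen. Compound 3 `CN(C)c1ccc(Cl)cc1Nc1nc2c(s1)CCCCc1nc(NC(=O)C(C)(C)C)sc1-2` differs from compound 2 by dimethylamino in place of methoxy on an aromatic carbon. Within the data shown here, no measured step touches this change, since the only step seen alters another part of the molecule. The expected step of a 1.1-fold higher number from compound 2 to compound 3 (0.04 log units; within the scatter) is therefore none beyond the scatter. Compound 3 is expected to give about 4500 nM, within 1500 nM to 14000 nM.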

Compound 3, half-maximal inhibitory concentration: 2100 nM
Compound 3: middle estimate off by 2.1-fold (0.33 log units), on the high side; the range from low to high includes it.
By their numbers in this assay, from the lowest: compounds 3 and 2 (each within the scatter of the next); then compound 1.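

Within the data shown here, this is the first reading at this position, on an aromatic carbon ortho to a large group and para to a chloro group. Dimethylamino in place of methoxy gives a 2.0-fold lower number from compound 2 to compound 3 (0.29 log units; within the scatter), so the swap, which adds one heavy atom, leaves the two compounds indistinguishable in this assay. No measurement available here explains this result.

Still open, from the compounds shown here alone, is whether a primary amine or a morpholine ring at this position would move the number beyond the scatter. Also open, going by these compounds, is whether dimethylamino would read the same with the free amine of compound 1 in place of the tert-butylcarbonyl amide.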